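Phenyl for thiophen-2-yl on the hydrazone carbon

The compounds below may be only part of what the source reports. "The series", "measured", "known", "first", "only" and "open" are said of these compounds alone.

Compound 1 `CCCSc1nc(N/N=C/c2cccs2)c2nnn(Cc3ccccc3)c2n1` shares its core with compound 2 `CCCSc1nc(N/N=C(\C)c2ccccc2O)c2nnn(Cc3ccc(F)cc3)c2n1`. In a functional assay on MGC-803 cells (Homo sapiens) for antiproliferative activity, read by MTT assay, with a stated time of 72 h (a higher number here means a weaker inhibitor, a lower number a stronger inhibitor), compound 1 gives only a limit, > 64000 nM, and not a number. Within the data shown here, compound 1 thus stands at the limit of > 64000 nM in this assay, at which 1 of the 2 values shown sits, the weak end of what has been measured in this assay so far. In this assay compound 2 gives 11000 nM. Compound 3 `CCCSc1nc(N/N=C/c2ccccc2)c2nnn(Cc3ccccc3)c2n1` differs from compound 1 in one place: phenyl in place of thiophen-2-yl on a carbon with a double bond to nitrogen. Among the measured compounds shown here, no step between two measured compounds is available to calibrate this change, so the size of the step in this assay is open; a small step in either direction, or none beyond the scatter, is the expectation. For compound 3 the expected value in this assay is estimated at 60000 nM, with a range from 15000 nM to 200000 nM. The implied step, an at least 1.0-fold lower number from compound 1 to compound 3 (0.02 log units; that floor lies within the scatter), is expected to be small. A limit rather than a number remains the likelier outcome for compound 3.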

Compound 3, half-maximal inhibitory concentration: > 64000 nM
Compound 3: no number, only a limit; the forecaster's own chance of this, stated with the estimate: 60%; middle value at least 1.0-fold (0.02 log units) away from the limit.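

In this assay, among these compounds, compound 1 and compound 3 each give only a limit and not a number, so no step between them can be read: the limit of > 64000 nM in this assay, at which 2 of the 3 values shown sit. Left open is whether phenyl and thiophen-2-yl on this carbon differ at all in this assay.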